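A few compounds are considered here, and "the series" means these few. Any claim that something is new, unique, unknown or untested is made for them only; others in the source may bear on it.

Measured compounds in a functional assay on HCT-116 cells (Homo sapiens) for inhibition, read by colorimetric assay, with a stated time of 3 days; on this read-out higher numbers stand for weaker inhibition and lower numbers for stronger inhibition: compound 1 `O=C(CCCCCCNC(=O)C(O)(O)C(F)(F)F)Nc1nccs1` gives 10800 nM; compound 2 `CCOc1ccc(-c2cnc(NC(=O)CCCCCCNC(=O)C(O)(O)C(F)(F)F)s2)cc1` gives 4050 nM; compound 3 `O=C(CCCCCCNC(=O)C(O)(O)C(F)(F)F)Nc1ncc(-c2ccc(O)cc2)s1` gives 1020 nM.

Compound 1 holds the highest number of the three, set apart from compound 2 by a 2.7-fold lower number from compound 1 to compound 2 (0.43 log units; beyond the scatter) and from compound 3 by an 11-fold lower number from compound 1 to compound 3 (1.02 log units; beyond the scatter). Compound 4 `O=C(CCCCCCNC(=O)C(O)(O)C(F)(F)F)Nc1nc2ccccc2o1` carries 1,3-benzoxazol-2-yl in place of 1,3-thiazol-2-yl on an amide-type nitrogen. Going by the values given here, no measured step replaces the ring on the amide-type nitrogen itself; both steps from compound 1 add an aryl group on an aromatic carbon of that ring, and both lower the number. Enlarging the heteroaryl to a fused bicycle is a different change, so the direction is uncertain, with a modest drop considered somewhat more likely than a rise. Compound 4 is therefore expected near 5000 nM, within 1200 nM to 20000 nM; this estimate means a step of a 2.2-fold lower number from compound 1 to compound 4 (0.33 log units; beyond the scatter).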

Compound 4, half-maximal inhibitory concentration: 3450 nM
Compound 4: the middle estimate sits 1.4-fold (0.16 log units) above what was measured; measured number inside the range.
By their numbers in this assay, from the lowest: compound 3; then compounds 4 and 2 (each within the scatter of the next); then compound 1.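

Placing 1,3-benzoxazol-2-yl in place of 1,3-thiazol-2-yl on an amide-type nitrogen gives a 3.1-fold lower number from compound 1 to compound 4 (0.50 log units; beyond the scatter) in this assay and shows that the number can also fall when the ring on that nitrogen itself is exchanged, not only when an aryl group is added on an aromatic carbon. Nothing in the available data accounts for this step. Still open, from the compounds shown here alone, is whether the six-membered aromatic ring or the exchange of sulfur for oxygen carries the step, which a 1,3-benzothiazol-2-yl group on the same nitrogen would separate. Also open, going by these compounds, is how a hydroxyl or an amine on that six-membered ring would read.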